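The source may report more compounds than this note shows. Statements on the series, on what has been measured and on what is new or still open speak of the compounds shown alone.

Measured so far:
compound 1 `COc1ccc(N2CCN(C(=S)SCc3ccc(C(=O)Nc4ccccc4N)cc3)CC2)cc1` gives 35.9%
compound 2 `Nc1ccccc1NC(=O)c1ccc(CSC(=S)N2CCN(c3ccc(F)cc3)CC2)cc1` gives 76.3%
compound 3 `Nc1ccccc1NC(=O)c1ccc(CSC(=S)N2CCN(c3ncccn3)CC2)cc1` gives 67.9%

In a functional assay on A-375 cells (Homo sapiens) for antiproliferative activity, read by CCK-8 assay, with a stated time of 72 h, tested at 8 uM (a higher number here means a stronger effect of the compound at the concentration tested, a lower number a weaker effect), compound 3 stands second highest of the three numbers. Its nearest neighbour is compound 2, and the step of a number 8.4 percentage points lower from compound 2 to compound 3 (within the scatter) lies within the scatter, so the two cannot be ordered. Its furthest neighbour is compound 1, and the step of a number 32 percentage points higher from compound 1 to compound 3 (beyond the scatter) is large.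

Compound 4 `Nc1ccccc1NC(=O)c1ccc(CSC(=S)N2CCN(Cc3cccnc3)CC2)cc1` differs from compound 3 in one place: (pyridin-3-yl)methyl in place of pyrimidin-2-yl on an amine nitrogen in a ring. All three measured steps change the group on the same ring nitrogen and therefore bear on this one. Two of them are large, a number 40.4 percentage points higher from compound 1 to compound 2 (beyond the scatter) and a number 32 percentage points higher from compound 1 to compound 3 (beyond the scatter), while a number 8.4 percentage points lower from compound 2 to compound 3 (within the scatter) is small. So a change at this position can move the read-out by a great deal or hardly at all. For the measured compounds named here, none of the measured compounds carries a methylene-linked aromatic group at this nitrogen, so the direction cannot be read from the data; the numbers so far span a wide band, and compound 4 is expected to fall inside it. Compound 4 is expected to give 60%, with a range from 35% to 80%. The expected step of a number 7.9 percentage points lower from compound 3 to compound 4 (within the scatter) is therefore estimated to be small relative to the scatter, but with wide uncertainty.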

Compound 4, a percentage reported as inhibition, at one concentration (the size of the read-out at that concentration, not a potency): 89.2%
Compound 4: middle estimate off by 29.2 percentage points, on the low side; measured number above the stated range.
By their numbers in this assay, from the lowest: compound 1; then compounds 3 and 2 (each within the scatter of the next); then compound 4.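

In this assay, (pyridin-3-yl)methyl on the amine nitrogen in the ring lifts the read-out beyond the scatter against each of the three earlier groups: a number 21.3 percentage points higher from compound 3 to compound 4 (beyond the scatter), a number 12.9 percentage points higher from compound 2 to compound 4 (beyond the scatter) and a number 53.3 percentage points higher from compound 1 to compound 4 (beyond the scatter). For the compounds shown here, compound 4 therefore stands highest of the four, which shows that the band set by the earlier compounds was not the upper limit at this nitrogen and that a methylene-linked aromatic group is not only accepted here but gives the strongest effect seen so far at the concentration tested. No independent measurement is available to explain why this group outperforms the others.

Going by these compounds, the change brings in the methylene and replaces the ring in one step, so the share of each in the gain stays open; a benzyl group and a pyridin-3-yl group carried on the nitrogen without the methylene would separate the two. Whether a longer chain, such as an ethylene link to the same pyridine ring, raises or lowers the read-out also stays open, and a single-concentration read-out gives no potency for any of these compounds.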